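This account rests on a few compounds, and the source may have more. Where it says the series, first, only, none or still open, it means among the compounds named here.

Three compounds share one core and differ only in the group carried on the oxygen. Compound 1 `COCNc1n[n+]([O-])c2ccccc2[n+]1[O-]` gives 4270 nM in a functional assay on PC-3 cells (Homo sapiens) for cytotoxicity, read by MTT assay, with a stated time of 72 h; on this read-out higher numbers stand for weaker inhibition and lower numbers for stronger inhibition. Compound 2 `[O-][n+]1nc(NCOC2CCCCC2)[n+]([O-])c2ccccc21` gives 6670 nM in this assay, and a 1.6-fold higher number from compound 1 to compound 2 (0.19 log units; within the scatter). Compound 3 `CCCCCCCOCNc1n[n+]([O-])c2ccccc2[n+]1[O-]` gives 390 nM in this assay, the lowest of the three numbers, with an 11-fold lower number from compound 1 to compound 3 (1.04 log units; beyond the scatter) and a 17-fold lower number from compound 2 to compound 3 (1.23 log units; beyond the scatter).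

Compound 4 `CCCCCOCNc1n[n+]([O-])c2ccccc2[n+]1[O-]` keeps the heptyl chain of compound 3 but cut short: hydrogen in place of ethyl on a saturated chain carbon, five bonds along the chain from an oxygen on a saturated carbon. The two steps that bear on this are those leading into compound 3, where a small group on the oxygen was exchanged for the long chain and the number fell by a large margin each time. Taking two carbons off that chain is expected to move the number back toward those of compound 1 and compound 2, though only partway, since most of the chain remains. The expected step is a 2.6-fold higher number from compound 3 to compound 4 (0.41 log units; beyond the scatter). Compound 4 is thus expected to give about 1000 nM in this assay, with a range from 400 nM to 3000 nM.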

Compound 4, half-maximal inhibitory concentration: 8510 nM
The estimate for compound 4 lay 8.5-fold (0.93 log units) below the measured number; measured number above the stated range.
By their numbers in this assay, from the lowest: compound 3; then compounds 1, 2 and 4 (each within the scatter of the next).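

In this assay, going by these compounds alone, the low number of compound 3 does not survive the loss of ethyl at this place, five bonds along the chain from an oxygen on a saturated carbon: the change is large (a 22-fold higher number from compound 3 to compound 4 (1.34 log units; beyond the scatter)), not the partial move that the earlier compounds might have suggested. The pentyl chain keeps nothing of that advantage, since compound 4 stands within the scatter of the cyclohexyl and methyl compounds (a 1.3-fold higher number from compound 2 to compound 4 (0.11 log units; within the scatter); a 2.0-fold higher number from compound 1 to compound 4 (0.30 log units; within the scatter)), so among these four compounds only the heptyl chain stands apart. No evidence at hand bears on this result.

Going by these compounds, whether a hexyl chain would give a number nearer compound 3 or nearer compound 4 remains open, as does whether a longer chain such as octyl or decyl would lower the number further. Also open, on these data alone, is whether a heptyl chain ending in an amine or a carboxylic acid would keep the number of compound 3.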